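The source may report more compounds than this note shows. Statements on the series, on what has been measured and on what is new or still open speak of the compounds shown alone.

Measured so far:
compound 1 `COc1ccc(COC(=O)[C@H](CSCC2CCCCC2)NC(=O)OC(C)(C)C)cc1` — 610 nM
compound 2 `O=C(N[C@@H](CSCC1CCCCC1)C(=O)NCc1ccc(Oc2ccccc2)cc1)[C@@H]1CSCN1` — 290 nM
compound 3 `CC(C)(C)OC(=O)N1CSC[C@H]1C(=O)N[C@@H](CSCC1CCCCC1)C(=O)NCc1ccc(O)cc1` — 1800 nM

In an assay on IMR-32 cells for inhibition of Voltage-dependent N-type calcium channel subunit alpha-1B (Homo sapiens) (a lower number here means a stronger inhibitor, a higher number a weaker inhibitor), compound 2 gives 290 nM, the lowest of the three numbers. Compound 1 gives 610 nM, and compound 3 gives 1800 nM; both gaps from compound 2 lie beyond the scatter. Compound 3 differs from compound 2 in more than one place, so its higher number cannot be laid on any single change.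

Compound 4 `COC(=O)N1CSC[C@H]1C(=O)N[C@@H](CSCC1CCCCC1)C(=O)NCc1ccc(Oc2ccccc2)cc1` has not yet been measured. It differs from compound 2 in one place: methoxycarbonyl in place of hydrogen on an amine nitrogen in a ring. Going by the values given here, no measured pair isolates this change. Compound 3 carries a related carbamate on the amine nitrogen in the ring together with a different tail and gives 1800 nM; that is the only hint available, and it points toward a weaker compound. For compound 4 a moderate loss is expected, the estimated step being a 2.4-fold higher number from compound 2 to compound 4 (0.38 log units; beyond the scatter). Compound 4 is estimated at 700 nM, within 250 nM to 2000 nM.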

Compound 4, half-maximal inhibitory concentration: 120 nM
Estimate against measurement, compound 4: 5.8-fold (0.77 log units) above; the whole stated range lies above it.
By their numbers in this assay, from the lowest: compound 4; then compound 2; then compound 1; then compound 3.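

In this assay, the amine nitrogen of the 1,3-thiazolidin-4-yl ring need not keep its hydrogen: methoxycarbonyl in that place gives a 2.4-fold lower number from compound 2 to compound 4 (0.38 log units; beyond the scatter), a modest gain. Going by these compounds alone, this is the first step that changes one place only, so it gives the first clean reading at this position, and that reading shows a carbamate on this nitrogen is compatible with a lower number when the rest of compound 2 is kept. Nothing at hand accounts for the size or direction of the step.

On these data alone, whether an acetyl group or a plain methyl group on the same nitrogen would give a similar step remains open. Also open, as far as these compounds go, is whether the gain carries over to a different tail on the shared core.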